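The compounds below may be only part of what the source reports. "The series", "measured", "known", "first", "only" and "open" are said of these compounds alone.

Working notes on the series. In a functional assay on A549 cells (Homo sapiens) for cytotoxicity, read by MTT assay, with a stated time of 72 h (on this read-out higher numbers stand for weaker inhibition and lower numbers for stronger inhibition), compound 3 `C#CCn1cc(C(=O)N[C@@H](C)CCOC(=O)[C@H]2CCCN2C(=O)OC(C)(C)C)c(=O)c2ccc(Cl)nc21` gives > 10000 nM, a limit of the assay. Compound 1 `C#CCn1cc(C(=O)NCCCOC(=O)[C@H]2CCCN2C(=O)OC(C)(C)C)c(=O)c2ccc(Cl)nc21` gives > 10000 nM, likewise a limit. Compound 2 `C#CCn1cc(C(=O)NCCCOC(=O)[C@H](C)NC(=O)OC(C)(C)C)c(=O)c2ccc(Cl)nc21` gives > 10000 nM, again a limit. Compound 4 `C#CCn1cc(C(=O)N[C@@H](C)CCOC(=O)[C@H](C)NC(=O)OC(C)(C)C)c(=O)c2ccc(Cl)nc21` differs from compound 3 by 1-((tert-butoxycarbonyl)amino)ethyl in place of 1-(tert-butoxycarbonyl)pyrrolidin-2-yl on a carbonyl carbon. The same change made on compound 1 gave a step that the two limits leave unreadable from compound 1 to compound 2, and the methyl step gave a step that the two limits leave unreadable from compound 1 to compound 3; both are unreadable, since (the limit of > 10000 nM in this assay, at which 3 of the 3 values shown sit). No direction can be taken from them. Compound 4 is therefore expected to sit at the limit as well, estimated at 20000 nM with a range from 10000 nM to 60000 nM. The expected step that the limit leaves unreadable from compound 3 to compound 4 is an estimate only, not a readable change beyond the scatter.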

Compound 4, half-maximal inhibitory concentration: > 10000 nM
Compound 4: only a limit was reported; the forecaster's own chance of this, stated with the estimate: 85%; the middle value does not contradict the limit.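

The steps to compound 4 from compound 3 and from compound 2 cannot be read: the limit of > 10000 nM in this assay, at which 4 of the 4 values shown sit. The compounds shown leave open whether either change, the 1-((tert-butoxycarbonyl)amino)ethyl group or the methyl, alters the read-out at all.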